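Series notes: replacing the aryl group of compound 1

The source may hold more compounds than are shown below. What is called first, only, known or untested is meant among the compounds shown, and "the series" means these compounds.

- compound 1 `Cc1nc(-c2ccccc2Cl)c(C(=O)N2CCN(c3cccc(Cl)c3)CC2)o1`: 132 nM
- compound 2 `CCc1nc(-c2ccccc2Cl)c(C(=O)N2CCN(c3cccc(Cl)c3)CC2)o1`: 98.9 nM

In a functional assay on HL-60 cells (Homo sapiens) for inhibition, read by MTT assay, with a stated time of 72 h (a lower number here means a stronger inhibitor, a higher number a weaker inhibitor), compound 1 gives 132 nM. Going by the values given here, only one other measurement stands beside it, and that one lies within the scatter: a 1.3-fold lower number from compound 1 to compound 2 (0.13 log units; within the scatter). The two compounds therefore cannot be ranked.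

Compound 3 `Cc1nc(-c2cccc(O)c2)c(C(=O)N2CCN(c3cccc(Cl)c3)CC2)o1` has not yet been measured. It differs from compound 1 as follows: 3-hydroxyphenyl in place of 2-chlorophenyl on an aromatic carbon. The exchange sits next to the ring nitrogen, and the group entering carries a hydrogen-bond donor, which the group leaving does not.

Among the compounds with values here, the single measured step, a 1.3-fold lower number from compound 1 to compound 2 (0.13 log units; within the scatter), is a change on a saturated chain carbon, not on this aromatic carbon. It says little here beyond showing that one small change at another place stayed within the scatter. Within the data shown here, no measured step covers the exchange of this aryl group, so the data fix neither its size nor its direction. A step larger than the measured one is plausible, and a slight lean towards a higher number is only a judgement.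

The step expected in this assay is a 1.5-fold higher number from compound 1 to compound 3 (0.18 log units; within the scatter).

For compound 3 the estimated value is 200 nM, with an expected range from 40 nM to 1000 nM.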

Compound 3, half-maximal inhibitory concentration: 105 nM
For compound 3 the middle estimate is 1.9-fold (0.28 log units) above the measured one, and the stated range covers the measured number.
By their numbers in this assay, from the lowest: compounds 2, 3 and 1 (each within the scatter of the next).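

In this assay, the exchange of 2-chlorophenyl for 3-hydroxyphenyl on this aromatic carbon gives a 1.3-fold lower number from compound 1 to compound 3 (0.10 log units; within the scatter). Going by these compounds alone, this is the first measured step at this position, and it shows that a replacement with the same heavy-atom count, but with a hydrogen-bond donor and acceptor that 2-chlorophenyl lacks, leaves compound 3 within the scatter of compound 1. The chlorine is therefore not required for activity in the nanomolar range seen here, and the donor brings no readable gain or loss. No evidence on the reason for this result is available.

This single exchange alters both the substituent and its place on the phenyl ring, so the compounds shown do not separate the two changes. Also open, going by these compounds, is how far this position can be varied: the effect in this assay of a carboxylic acid or an amine on the phenyl ring, or of a longer chain in place of the aryl group, cannot be judged from these compounds.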